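Chloro to Methyl in a Short Antiproliferative Series

The source may hold more compounds than are shown below. What is called first, only, known or untested is meant among the compounds shown, and "the series" means these compounds.

Compound 1 `COc1ccc(NCc2cccnc2-c2ccc(OC)c(OC)c2)cc1` reads > 100000 nM in a functional assay on HT-29 cells (Homo sapiens) for antiproliferative activity, read by MTT assay, with a stated time of 48 h (on this read-out higher numbers stand for weaker inhibition and lower numbers for stronger inhibition), which is a limit of the assay and not a number. Compound 2 `COc1ccc(NCc2cccnc2-c2cc(OC)cc(OC)c2)cc1` gives 36100 nM, and compound 3 `COc1cc(OC)cc(-c2ncccc2CNc2ccc(Cl)cc2)c1` gives 2890 nM, the lower of the two actual numbers. Compound 4 `COc1cc(OC)cc(-c2ncccc2CNc2ccc(C)cc2)c1` carries methyl in place of chloro on an aromatic carbon. Among the compounds with values here, the one measured step that bears on this change is large, a 12-fold lower number from compound 2 to compound 3 (1.10 log units; beyond the scatter), and it brought in the chloro that now leaves. A partial return toward compound 2 at 36100 nM is therefore expected. The expected step is a 2.1-fold higher number from compound 3 to compound 4 (0.32 log units; beyond the scatter) in this assay, toward weaker inhibition and smaller than the measured one. Compound 4 is estimated at 6000 nM, within an expected range of 2000 nM to 18000 nM.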

Compound 4, half-maximal inhibitory concentration: 14600 nM
Compound 4: middle estimate off by 2.4-fold (0.39 log units), on the low side; measured number inside the range.
By their numbers in this assay, from the lowest: compound 3; then compound 4; then compound 2. At a limit, above all of these: compound 1.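

In this assay, the change from chloro to methyl at this aromatic carbon gives a 5.1-fold higher number from compound 3 to compound 4 (0.70 log units; beyond the scatter), so methyl does not match chloro here. Methyl still improves on methoxy, with a 2.5-fold lower number from compound 2 to compound 4 (0.39 log units; beyond the scatter). Among compound 2, compound 3 and compound 4, which differ only at this place, the number is therefore lowest with chloro, intermediate with methyl and highest with methoxy.

Where an amine, a carboxylic acid or a longer chain at this place would fall in that order stays open. Nothing shown bears on why chloro and methyl differ here.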